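Swapping a Fluorinated Ring for a Short Chain

A few compounds are considered here, and "the series" means these few. Any claim that something is new, unique, unknown or untested is made for them only; others in the source may bear on it.

Compound 1, `CCc1ccccc1Nc1nc(Cl)nc(Cl)n1`: -2.26% in an assay for inhibition of Pro-cathepsin H (Homo sapiens), read by fluorescence, tested at 50 uM; on this read-out higher numbers stand for more inhibition at the one concentration tested (going by the name of the read-out) and lower numbers for less inhibition.
Compound 2, `O=c1nc(SCc2ccccc2)nc(SCc2ccccc2F)[nH]1`: "not determined" (no result reported) in this assay.

In this assay compound 1 gives essentially no inhibition at -2.26%. For compound 2 no single number is available, so it cannot be placed against compound 1. Compound 3, `CCCCSc1nc(SCc2ccccc2)nc(=O)[nH]1`, differs from compound 2 by propyl in place of 2-fluorophenyl on a saturated chain carbon bound to a sulfur. Among the measured compounds shown here, no measured step between two related compounds exists here, so the size and direction of this change cannot be read from the data, and no step beyond the scatter is expected in either direction. Compound 3 is therefore expected to show 5%, in a range from -10% to 25%.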

Compound 3, a percentage reported as inhibition, at one concentration (the size of the read-out at that concentration, not a potency): -1.81%
Estimate against measurement, compound 3: 6.8 percentage points above; measured number inside the range.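

Among the compounds shown here, with no single number for compound 2 in this assay, no step to compound 3 can be read, though compound 3 gives -1.81%. Nothing shown here bears on this result. From the compounds shown here alone, whether exchanging 2-fluorophenyl for propyl changes inhibition remains open.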